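A few compounds are considered here, and "the series" means these few. Any claim that something is new, unique, unknown or untested is made for them only; others in the source may bear on it.

Measured in a toxicity assay on HEK293 cells (Homo sapiens) for inhibition, read by resazurin assay, with a stated time of 24 h; a lower number here means that less compound is tolerated, a higher number that more compound is tolerated:
- Compound 1 `Cn1c([N+](=O)[O-])cnc1C(=O)NCc1ccc(F)cc1`: > 100000 nM
- Compound 2 `NC(=O)c1nc([N+](=O)[O-])cn1Cc1ccc(F)cc1`: > 100000 nM
- Compound 3 `NC(=O)c1nc([N+](=O)[O-])cn1Cc1ccc(OC(F)(F)F)cc1`: > 100000 nM

For compound 3, the entry > 100000 nM is a limit of the assay and not a number. It shares this position with compound 1 and compound 2, as the record shows (the limit of > 100000 nM in this assay, at which 3 of the 3 values shown sit). Compound 4 `CN(C)C(=O)c1nc([N+](=O)[O-])cn1Cc1ccc(OC(F)(F)F)cc1` carries dimethylamino in place of amino on a carbonyl carbon. Going by the values given here, the only measured step is a step that the two limits leave unreadable from compound 2 to compound 3, and it concerns trifluoromethoxy in place of fluoro on an aromatic carbon, so no measured step covers this change. In this assay, no shift beyond the scatter is therefore expected in either direction, and the expected step is a number no higher from compound 3 to compound 4 (the limit leaves the size open). The estimate for compound 4 is 100000 nM, with an expected range of 40000 nM to 200000 nM.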

Compound 4, half-maximal cytotoxic concentration: > 100000 nM
Compound 4: a limit, no number (the forecaster's own chance of this, stated with the estimate: 75%); the middle value lies on the limit itself.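

Compound 3 and compound 4 both stand at a limit of the assay and not at a number, so no step can be read between them: the limit of > 100000 nM in this assay, at which 4 of the 4 values shown sit. The compounds shown leave open where their actual values lie in this assay, and whether dimethylamino in place of amino on a carbonyl carbon shifts them at all.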